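A few compounds are considered here, and "the series" means these few. Any claim that something is new, unique, unknown or untested is made for them only; others in the source may bear on it.

Compound 1 `C=C1C[C@]23C[C@@]1(O)CC[C@H]2c1cc(Br)c(O)c(C)c1[C@@H]3Cn1cc(-c2ccc(C)cc2)nn1` in a functional assay on A549 cells (Homo sapiens) for cytotoxicity, read by MTT assay, with a stated time of 4 days (a higher number here means a weaker inhibitor, a lower number a stronger inhibitor), gives > 20000 nM, which is a limit of the assay and not a number. Among the compounds with values here, compound 2 `C=C1C[C@]23C[C@@]1(O)CC[C@H]2c1cc(Br)c(O)c(C)c1[C@@H]3Cn1cc(-c2ccc(F)cc2)nn1` in this assay gives 17900 nM, the only number so far. Within the data shown here, the one measured step is an at least 1.1-fold lower number from compound 1 to compound 2 (0.04 log units; that floor lies within the scatter), and it rests on (the limit of > 20000 nM in this assay, at which 1 of the 2 values shown sits). Compound 3 `C=C1C[C@]23C[C@@]1(O)CC[C@H]2c1cc(Br)c(O)c(C)c1[C@@H]3Cn1cc(-c2ccc(C(F)(F)F)cc2)nn1` differs from compound 2 by trifluoromethyl in place of fluoro on an aromatic carbon. Among the measured compounds shown here, only that single step bears on the change, and its floor lies within the scatter, so no step beyond the scatter is expected in this assay. Compound 3 is therefore expected near 18000 nM, between 7000 nM and 50000 nM, an expected step of a 1.0-fold higher number from compound 2 to compound 3 (0.00 log units; within the scatter).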

Compound 3, half-maximal inhibitory concentration: 9280 nM
Compound 3: middle estimate off by 1.9-fold (0.29 log units), on the high side; the measured number falls inside the stated range.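

In this assay, the exchange of 4-fluorophenyl for 4-(trifluoromethyl)phenyl gives a 1.9-fold lower number from compound 2 to compound 3 (0.29 log units; within the scatter), so fluoro and trifluoromethyl at this position are not separated. Within the data shown here, the exchange of methyl for trifluoromethyl on the same aromatic carbon is the first step to pass the scatter, with an at least 2.1-fold lower number from compound 1 to compound 3 (0.33 log units; beyond the scatter). That step is only a floor, as the value of compound 1 is a limit and not a number: the limit of > 20000 nM in this assay, at which 1 of the 3 values shown sits.

Open, going by these compounds, is how an amine, a carboxylic acid or a methoxy group on this aromatic carbon would read in this assay.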